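Working notes on compound 1 and a chloro analogue

This account rests on a few compounds, and the source may have more. Where it says the series, first, only, none or still open, it means among the compounds named here.

Measured so far, in a functional assay on A549 cells (Homo sapiens) for antiproliferative activity, read by CCK-8 assay, with a stated time of 72 h; a lower number here means a stronger inhibitor, a higher number a weaker inhibitor:
compound 1 `CC1=NN(c2ccccc2)C(=O)C12C=CC(=O)C=C2c1ccccc1` gives 16500 nM
compound 2 `CC1=NN(c2cccc(Cl)c2)C(=O)C12C=CC(=O)C=C2c1cccc(C)c1` gives 20100 nM

Compound 1 holds the lower of the two numbers, but compound 2 stands within the scatter of it, so no order between them is claimed. Compound 3 `CC1=NN(c2ccc(Cl)cc2)C(=O)C12C=CC(=O)C=C2c1ccccc1` differs from compound 1 by chloro in place of hydrogen on an aromatic carbon. Going by the values given here, no pair of measured compounds differs by this change, so its effect in this assay is unknown; the expected step from compound 1 is small, and a 1.1-fold lower number from compound 1 to compound 3 (0.04 log units; within the scatter) is estimated to stay within the scatter. Compound 3 is therefore expected at 15000 nM, in a range from 6000 nM to 38000 nM.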

Compound 3, half-maximal inhibitory concentration: > 100000 nM
Compound 3: a limit, no number (the forecaster's own chance of this, stated with the estimate: 10%); at least 6.6-fold (0.82 log units) between middle value and limit.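

In this assay, this position on the N-aryl group... 

Correction to the above: in this assay, phenyl to 4-chlorophenyl is not a neutral change, giving an at least 6.0-fold higher number from compound 1 to compound 3 (0.78 log units; beyond the scatter). Going by these compounds alone, no earlier pair of compounds showed this change, and this is the first sign that chloro para to a large group can cost activity. Compound 3 gives a limit and not a number: the limit of > 100000 nM in this assay, at which 1 of the 3 values shown sits.

The full size of the step cannot be read from that limit. From the compounds shown here alone, whether fluoro, methoxy or an amine at this place would behave like chloro stays open, as does whether chloro at another place on this ring would do the same.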